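This account rests on a few compounds, and the source may have more. Where it says the series, first, only, none or still open, it means among the compounds named here.

For the measured compounds named here, compound 1 `CC(C)(C)c1ccc(/C=C/C(=O)c2ccc(OCC(=O)N[C@H]3CCOC3=O)cc2)cc1` is the one compound here with an actual number in a functional assay on PC-3 cells (Homo sapiens) for antiproliferative activity, read by MTT assay, with a stated time of 72 h; a lower number here means a stronger inhibitor, a higher number a weaker inhibitor: compound 1 gives 10600 nM. Compound 2 `CC(C)c1ccc(NCC(=O)N[C@H]2CCOC2=O)cc1` is recorded in this assay only as a limit, > 64000 nM, which is the limit of > 64000 nM in this assay, at which 1 of the 2 values shown sits. Compound 3 `O=C(COc1ccc(C(=O)/C=C/c2ccc(Br)cc2)cc1)N[C@H]1CCOC1=O` differs from compound 1 by bromo in place of tert-butyl on an aromatic carbon. Going by the values given here, no measured pair shows a change of this kind, so the step is expected to stay within the usual scatter, with a 1.1-fold higher number from compound 1 to compound 3 (0.05 log units; within the scatter) expected as no more than a small shift in this assay. Compound 3 is accordingly estimated at 12000 nM, within a range from 4000 nM to 40000 nM.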

Compound 3, half-maximal inhibitory concentration: > 64000 nM
Compound 3 was reported as a limit; the forecaster's own chance of this, stated with the estimate: 15%; at least 5.3-fold (0.72 log units) between middle value and limit.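

Putting bromo in place of tert-butyl on this aromatic carbon, para to a large group, gives an at least 6.0-fold higher number from compound 1 to compound 3 (0.78 log units; beyond the scatter) in this assay, the first sign that activity depends on the group held here. Compound 1 thus keeps a measurable number only with tert-butyl in this place among the compounds shown. The true size of the step remains unknown, as the value of compound 3 is only a limit: the limit of > 64000 nM in this assay, at which 2 of the 3 values shown sit.

On these data alone, whether a methyl, an isopropyl or a methoxy group at this carbon would behave like tert-butyl or like bromo remains open. So does whether a chloro or a trifluoromethyl group would retain any measurable activity.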